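A few compounds are considered here, and "the series" means these few. Any claim that something is new, unique, unknown or untested is made for them only; others in the source may bear on it.

Measured so far in an assay on isolated protein for inhibition of activin receptor type-2A (Homo sapiens), read by 33P incorporation, with a stated time of 20 min, in the presence of a further agent that is not named here; on this read-out higher numbers stand for weaker inhibition and lower numbers for stronger inhibition: compound 1 `COc1cc(-c2cnn3cc(OC)c([C@@H]4COC(C)(C)C4)nc23)ccn1` gives 5300 nM; compound 2 `COc1cc(-c2cnn3cc(OC)c(C4CCCC4)nc23)ccn1` gives 2900 nM.

Compound 2 is not separated from compound 1 beyond the scatter: a 1.8-fold lower number from compound 1 to compound 2 (0.26 log units; within the scatter). Compound 3 `COc1cc(-c2cnn3cc(OC)c([C@H]4COC(C)(C)C4)nc23)ccn1` differs from compound 2 by a group of 7 heavy atoms (6 carbon, 1 oxygen; one five-membered non-aromatic ring with 1 hetero atom) in place of a group of 5 heavy atoms (5 carbon; one five-membered non-aromatic ring of carbon only), on an aromatic carbon; it carries the other configuration of the group seen in compound 1. For the measured compounds named here, the only step that bears on it is the reverse of the one from compound 1 to compound 2, which stayed within the scatter, so no move beyond the scatter is expected in this assay. Compound 3 is therefore estimated at 5000 nM, range 2000 nM to 14000 nM, an expected step of a 1.7-fold higher number from compound 2 to compound 3 (0.24 log units; within the scatter).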

Compound 3, half-maximal inhibitory concentration: 4100 nM
Compound 3: middle estimate off by 1.2-fold (0.09 log units), on the high side; the measured number falls inside the stated range.
By their numbers in this assay, from the lowest: compounds 2, 3 and 1 (each within the scatter of the next).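

Reversing the stereocentre at the saturated ring carbon gives no separation beyond the scatter in this assay, with a 1.3-fold lower number from compound 1 to compound 3 (0.11 log units; within the scatter). This comparison isolates the configuration at that carbon: the fact that compounds 1 and 3 differ only in the configuration as drawn. The second configuration also stays within the scatter of cyclopentyl, with a 1.4-fold higher number from compound 2 to compound 3 (0.15 log units; within the scatter), so at this aromatic carbon neither configuration of the oxygen-containing ring separates from the all-carbon ring.

Still open, as far as these compounds go, is whether an amine or a longer chain on this aromatic carbon would separate from cyclopentyl beyond the scatter. Also open, from the compounds shown here alone, is what a hydroxyl group in place of the neighbouring methoxy group would do.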